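The source may hold more compounds than are shown below. What is called first, only, known or untested is meant among the compounds shown, and "the series" means these compounds.

In a functional assay on HepG2 cells (Homo sapiens) for inhibition, read by MTT assay, with a stated time of 48 h (a higher number here means a weaker inhibitor, a lower number a stronger inhibitor), compound 1 `CCSc1nnc(-c2cc(OC)c(OC)c(OC)c2)n1-c1ccc(OC)cc1` gives > 60000 nM, which is a limit of the assay and not a number. Among the measured compounds shown here, compound 2 `COc1ccc(-n2c(SCC(=O)c3ccccc3)nnc2-c2cc(OC)c(OC)c(OC)c2)cc1` reads 16200 nM, the only actual number so far. Compound 3 `COc1ccc(C(=O)CSc2nnc(-c3cc(OC)c(OC)c(OC)c3)n2-c2ccc(OC)cc2)cc1` differs from compound 2 by methoxy in place of hydrogen on an aromatic carbon of the benzoyl group. For the measured compounds named here, the only measured step, an at least 3.7-fold lower number from compound 1 to compound 2 (0.56 log units; beyond the scatter), put benzoyl in place of methyl on a saturated chain carbon bound to a sulfur. It is a different change and sets no size for this one, so no step beyond the scatter is expected. The estimated step is a 1.1-fold lower number from compound 2 to compound 3 (0.03 log units; within the scatter). For compound 3 the expected value is 15000 nM, with an estimated range of 6000 nM to 40000 nM.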

Compound 3, half-maximal inhibitory concentration: 18100 nM
For compound 3 the middle estimate is 1.2-fold (0.08 log units) below the measured one; low and high end bracket the measured number.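

Moving from phenyl to 4-methoxyphenyl at this position leaves the reading in this assay essentially unchanged, with a 1.1-fold higher number from compound 2 to compound 3 (0.05 log units; within the scatter). The (4-methoxyphenyl)carbonyl group in place of methyl on the chain carbon bound to sulfur still gives an at least 3.3-fold lower number from compound 1 to compound 3 (0.52 log units; beyond the scatter), so the step seen with benzoyl survives this added methoxy. The size of that step remains open-ended, as the value for compound 1 is a limit and not a number: the limit of > 60000 nM in this assay, at which 1 of the 3 values shown sits.

The compounds shown leave open whether an amine, a hydroxyl or a chlorine on this ring carbon would move the reading beyond the scatter. They also leave open whether a longer chain between sulfur and carbonyl would do so.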